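Replacing a Bulky Aryl Group with a Small Thiophene Ring

The source may hold more compounds than are shown below. What is called first, only, known or untested is meant among the compounds shown, and "the series" means these compounds.

Three measured compounds share one core and differ only in the group attached to the five-membered aromatic ring with 4 nitrogen. Compound 1 `CCCCCCCCc1ccc(OCC(=O)Cn2nnnc2SC)cc1` carries a methylsulfanyl group; in an assay on microsomes from brain for inhibition of Fatty-acid amide hydrolase 1 (Rattus norvegicus), read by fluorescence and HPLC, with a stated time of 60 min (a lower number here means a stronger inhibitor, a higher number a weaker inhibitor), compound 1 gives 22 nM. Compound 2 `CCCCCCCCc1ccc(OCC(=O)Cn2nnnc2-c2ccc(Cl)cc2)cc1` carries a 4-chlorophenyl group, and compound 2 gives 130 nM. Compound 3 `CCCCCCCCc1ccc(OCC(=O)Cn2nnnc2-c2ccc(S(=O)(=O)N(C)C)cc2)cc1` carries a 4-(dimethylsulfamoyl)phenyl group, and compound 3 gives 1400 nM, the highest of the three numbers. Compound 4 `CCCCCCCCc1ccc(OCC(=O)Cn2nnnc2-c2cccs2)cc1` is the next step: thiophen-2-yl in place of 4-(dimethylsulfamoyl)phenyl on an aromatic carbon. The measured steps that bear on this are an 11-fold higher number from compound 2 to compound 3 (1.03 log units; beyond the scatter) and a 64-fold higher number from compound 1 to compound 3 (1.80 log units; beyond the scatter), both showing that the 4-(dimethylsulfamoyl)phenyl group goes with a much higher number than smaller groups. Compound 4 is therefore expected to show a large drop, a 23-fold lower number from compound 3 to compound 4 (1.37 log units; beyond the scatter). The estimate for compound 4 is 60 nM, within a range from 20 nM to 200 nM.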

Compound 4, half-maximal inhibitory concentration: 55 nM
Beside the measured number, compound 4's estimate is 1.1-fold (0.04 log units) above it; low and high end bracket the measured number.
By their numbers in this assay, from the lowest: compound 1; then compound 4; then compound 2; then compound 3.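

In this assay, a large aryl group is not required for a low number here: thiophen-2-yl gives a 25-fold lower number from compound 3 to compound 4 (1.41 log units; beyond the scatter) and, against the smaller 4-chlorophenyl group, a 2.4-fold lower number from compound 2 to compound 4 (0.37 log units; beyond the scatter) on the same aromatic carbon. Even so, the ring does not match methylsulfanyl, with a 2.5-fold higher number from compound 1 to compound 4 (0.40 log units; beyond the scatter) in this series. No supporting measurement explains these differences. On these data alone, what an unsubstituted phenyl ring or an ethylsulfanyl group would give on this carbon remains open, so the roles of ring size and of the chlorine cannot yet be separated.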